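Cytotoxicity notes on a nitro-chlorobenzamide series

A few compounds are considered here, and "the series" means these few. Any claim that something is new, unique, unknown or untested is made for them only; others in the source may bear on it.

Measured so far:
compound 1, `Cc1cc(NC(=O)c2cc([N+](=O)[O-])ccc2Cl)cc(-c2nc3ccccc3s2)c1O`, > 25000 nM
compound 2, `O=C(Nc1nc(-c2ccc(Cl)cc2)cs1)c1cc([N+](=O)[O-])ccc1Cl`, 15000 nM

In an ADME assay on HEK293 cells (Homo sapiens) for cytotoxicity, with a stated time of 72 h (on this read-out lower numbers stand for an effect already at smaller amounts and higher numbers for an effect only at larger amounts of compound), compound 1 reaches only a limit, (the limit of > 25000 nM in this assay, at which 1 of the 2 values shown sits). Among the compounds with values here, compound 2 therefore stands as the only actual number in this assay, with 15000 nM. Compound 3, `O=C(Nc1nc(-c2cccc(F)c2)cs1)c1cc([N+](=O)[O-])ccc1Cl`, is still to be measured there. It differs from compound 2 by 3-fluorophenyl in place of 4-chlorophenyl on an aromatic carbon. Within the data shown here, with no measured step of this kind to draw on, only a small shift within the usual scatter is expected from compound 2 to compound 3, a 1.2-fold higher number from compound 2 to compound 3 (0.08 log units; within the scatter). Compound 3 is estimated at 18000 nM, in the range 7000 nM to 25000 nM.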

Compound 3, half-maximal effective concentration: 8700 nM
Compound 3: middle estimate off by 2.1-fold (0.32 log units), on the high side; measured number inside the range.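

This position now has its first measured step in this assay: 3-fluorophenyl in place of 4-chlorophenyl on the aromatic carbon next to the ring nitrogen gives a 1.7-fold lower number from compound 2 to compound 3 (0.24 log units; within the scatter) and stays within the usual scatter. The halogen and its place on the phenyl ring differ together in this pair, so their separate contributions cannot be read. Nothing measured on these compounds accounts for the step.

Still open, as far as these compounds go, is whether an amine or a carboxylic acid on that phenyl ring would shift the number beyond the scatter.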